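Cyclohexyloxy for Dichlorophenyl at the Aromatic Carbon

The source may hold more compounds than are shown below. What is called first, only, known or untested is meant among the compounds shown, and "the series" means these compounds.

Measured so far:
Compound 1 `Cc1c(C(=O)N=C(N)N)ccc(Cl)c1S(C)(=O)=O`: in a functional assay for inhibition of sodium/hydrogen exchanger (Oryctolagus cuniculus) (a lower number here means a stronger inhibitor, a higher number a weaker inhibitor), compound 1 gives 1300 nM.
Compound 2 `Cc1cc(-c2cc(Cl)cc(Cl)c2)c(S(C)(=O)=O)cc1C(=O)N=C(N)N`: in this assay compound 2 gives 130 nM.

Compound 2 has the lowest of the two numbers; compound 1 stands a step higher, and that gap lies beyond the scatter. Compound 3 `Cc1cc(OC2CCCCC2)c(S(C)(=O)=O)cc1C(=O)N=C(N)N` is not yet measured. It differs from compound 2 in one place: cyclohexyloxy in place of 3,5-dichlorophenyl on an aromatic carbon. Among the measured compounds shown here, no step between measured compounds covers this change, so the expectation rests on compound 2 alone. The step from compound 2 to compound 3 is estimated as a modest weakening, a 2.3-fold higher number from compound 2 to compound 3 (0.36 log units; beyond the scatter). Compound 3 is expected to give 300 nM, within 80 nM to 1500 nM.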

Compound 3, half-maximal inhibitory concentration: 37 nM
Compound 3: middle estimate off by 8.1-fold (0.91 log units), on the high side; measured number outside the range, below it.
By their numbers in this assay, from the lowest: compound 3; then compound 2; then compound 1.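

In this assay, cyclohexyloxy in place of 3,5-dichlorophenyl, ortho to the methylsulfonyl group, brings a 3.5-fold lower number from compound 2 to compound 3 (0.55 log units; beyond the scatter) and shows that an aromatic ring at this carbon is not needed for the stronger inhibition. The position accepts a non-aromatic ring joined through oxygen, and here that group outperforms the 3,5-dichlorophenyl of compound 2. Nothing available explains this step. As far as these compounds go, the change replaces the ring and adds the oxygen together, so the share of each remains unknown. From the compounds shown here alone, whether cyclopentyloxy, an open butoxy chain or a piperidine amine would hold or improve the number remains open.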